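Extending a urea on a shared core: compound 2 to compound 4

A few compounds are considered here, and "the series" means these few. Any claim that something is new, unique, unknown or untested is made for them only; others in the source may bear on it.

Three compounds here share one core, carrying a sulfonamide built on a fluorophenyl group. Compound 1 `CCCNc1nc2ccc(-c3cnc(Cl)c(NS(=O)(=O)c4ccc(F)cc4)c3)cc2s1` was not given a number in a functional assay on A549 cells (Homo sapiens) for antiproliferative activity, read by MTT assay, with a stated time of 72 h (on this read-out higher numbers stand for weaker inhibition and lower numbers for stronger inhibition), and for compound 1 the entry in this assay reads "not determined" (no result reported). Compound 3 `O=S(=O)(Nc1cc(-c2ccc3nc(NC4CC4)sc3c2)cnc1Cl)c1ccc(F)cc1` was likewise not given a number, and for compound 3 the entry in this assay reads "not determined" (no result reported); for each of these two no result was reported. For the measured compounds named here, compound 2 `CNC(=O)Nc1nc2ccc(-c3cnc(OC)c(NS(=O)(=O)c4ccc(F)cc4)c3)cc2s1` is therefore the only compound with a measured value, and in this assay compound 2 gives 1560 nM. That single number is the whole measured footing for what follows.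

Compound 4 `CCN(CC)CCNC(=O)Nc1nc2ccc(-c3cnc(OC)c(NS(=O)(=O)c4ccc(F)cc4)c3)cc2s1` is the untested compound. It differs from compound 2 in one place: (diethylamino)methyl in place of hydrogen on a saturated chain carbon bound to an amide-type nitrogen. Going by the values given here, no step between two measured compounds is available to show what this kind of extension does on this core, so any expectation must lean on compound 2 alone and on the modest size of the change, which leaves the rest of the molecule untouched.

The expected outcome is a shift no larger than the usual scatter of this assay, with no clear direction, so the estimated step from compound 2 to compound 4 is a 1.2-fold lower number from compound 2 to compound 4 (0.08 log units; within the scatter). Compound 4 is accordingly estimated to give about 1300 nM in this assay. The expected range for compound 4 runs from 400 nM to 4500 nM, reflecting the thin footing of one measured compound.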

Compound 4, half-maximal inhibitory concentration: 450 nM
Estimate against measurement, compound 4: 2.9-fold (0.46 log units) above; measured number inside the range.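

For the compounds shown here, changing methyl to 2-(diethylamino)ethyl on the urea gives the first readable step on this core: in this assay, the change brings a 3.5-fold lower number from compound 2 to compound 4 (0.54 log units; beyond the scatter). This shows that the position, a saturated chain carbon bound to an amide-type nitrogen, can carry a much longer chain ending in a diethylamino group without losing activity, and that inhibition here becomes stronger rather than weaker. This rests on one pair of compounds, so it marks a single favourable change and not a trend, and nothing available here explains why the number fell.

As far as these compounds go, it remains open whether the improvement depends on the tertiary amine at the end of the chain or on the added chain length alone, a question that a plain butyl chain with no nitrogen could help to settle. From the compounds shown here alone, the effect of other chain ends, such as a morpholine, a primary amine or a carboxylic acid, and of a shorter or longer link to the amine, also remains open.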